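Hydroxamic acid series: chloro to nitro on the aryl ketone

A few compounds are considered here, and "the series" means these few. Any claim that something is new, unique, unknown or untested is made for them only; others in the source may bear on it.

Measured compounds, all in an assay on isolated protein for inhibition of histone deacetylase HD2 (Zea mays), tested at 30 uM; on this read-out higher numbers stand for more inhibition at the one concentration tested (going by the name of the read-out) and lower numbers for less inhibition:
compound 1 `COc1ccc(C(=O)c2cc(/C=C/C(=O)NO)n(C)c2)cc1` gives 75.2%.
compound 2 `Cn1cc(C(=O)c2ccccc2)cc1/C=C/C(=O)NCCO` gives 0.9%.
compound 3 `Cn1cc(C(=O)c2ccc(Cl)cc2)cc1/C=C/C(=O)NO` gives 87%.

Compound 3 stands highest of the three numbers in this assay. The nearest is compound 1, separated by the step of a number 11.8 percentage points higher from compound 1 to compound 3 (beyond the scatter). The furthest is compound 2, whose hydroxyethyl amide in place of the hydroxamic acid leaves almost no inhibition, so compound 2 says nothing about substitution on the aryl ketone.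

The compound not yet measured is compound 4 `Cn1cc(C(=O)c2ccc([N+](=O)[O-])cc2)cc1/C=C/C(=O)NO`. It differs from compound 3 as follows: nitro in place of chloro on an aromatic carbon.

Among the measured compounds shown here, only one measured step bears on a change at this position, the step from methoxy to chloro, a number 11.8 percentage points higher from compound 1 to compound 3 (beyond the scatter), which was modest. For the measured compounds named here, no measured pair compares chloro with nitro, so the direction of the step from compound 3 to compound 4 is not fixed by these data. Given that compound 3 already lies near the top of the scale, a further rise has little room; a step within the scatter, or a small drop, is expected.

Compound 4 is therefore expected to give about 82% in this assay, within 65% to 95%, which is an expected step of a number 5 percentage points lower from compound 3 to compound 4 (within the scatter).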

Compound 4, a percentage reported as inhibition, at one concentration (the size of the read-out at that concentration, not a potency): 78%
Compound 4: the middle estimate sits 4 percentage points above what was measured; the range from low to high includes it.
By their numbers in this assay, from the lowest: compound 2; then compounds 1, 4 and 3 (each within the scatter of the next, the first and the last beyond it).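

In this assay, the step to nitro on the aromatic carbon para to a large group is a number 9 percentage points lower from compound 3 to compound 4 (within the scatter), and the comparison with methoxy at the same place is a number 2.8 percentage points higher from compound 1 to compound 4 (within the scatter), so compound 4 cannot be separated from either neighbour, even though a number 11.8 percentage points higher from compound 1 to compound 3 (beyond the scatter) lies beyond the scatter. At this position, then, a nitro group with its three heavy atoms and two hydrogen-bond acceptors keeps the inhibition of the series in the range set by the single chlorine atom and by methoxy, and among these three hydroxamic acids only the methoxy and chloro pair stands apart. Nothing on hand bears on why the steps have this size.

The compounds shown leave open whether an amine or a carboxylic acid at this same place would stay in that range, and how a hydroxamic acid with no group there at all would compare. A read-out at one concentration also leaves open how compound 1, compound 3 and compound 4 would compare at other concentrations.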